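Fluoro to amino on the benzyl ring

This account rests on a few compounds, and the source may have more. Where it says the series, first, only, none or still open, it means among the compounds named here.

Measured in a functional assay on MGC-803 cells (Homo sapiens) for antiproliferative activity, read by MTT assay, with a stated time of 48 h; on this read-out lower numbers stand for stronger inhibition and higher numbers for weaker inhibition:
- compound 1 `COc1ccc(CN(C(=O)CSc2nc3ccccc3s2)c2cc(OC)c(OC)c(OC)c2)cc1C`: 6360 nM
- compound 2 `COc1cc(N(Cc2ccc(C)cc2)C(=O)CSc2nc3ccccc3s2)cc(OC)c1OC`: 54200 nM
- compound 3 `COc1ccc(CN(C(=O)CSc2nc3ccccc3s2)c2cc(OC)c(OC)c(OC)c2)cc1F`: 416 nM

Compound 3 has the lowest number of the three, and its steps to both others lie beyond the scatter. The next analogue, compound 4 `COc1ccc(CN(C(=O)CSc2nc3ccccc3s2)c2cc(OC)c(OC)c(OC)c2)cc1N`, changes one group: amino in place of fluoro on an aromatic carbon. That is, amino in place of fluoro on an aromatic carbon, ortho to a methoxy group.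

Within the data shown here, two measured steps bear on this. Fluoro in place of methyl gave a 15-fold lower number from compound 1 to compound 3 (1.18 log units; beyond the scatter), a large step at the same carbon. The replacement of the whole benzyl aryl group gave a 130-fold lower number from compound 2 to compound 3 (2.11 log units; beyond the scatter), also large. Among the measured compounds shown here, no measured compound carries amino, so the direction of the change is not established. These steps show that this assay can respond strongly to this part of the structure, so a wide range is warranted, although no step beyond the scatter is expected as the central case. The expected step is a 1.7-fold lower number from compound 3 to compound 4 (0.22 log units; within the scatter). For compound 4 the estimated value is 250 nM, with an expected range of 40 nM to 2000 nM.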

Compound 4, half-maximal inhibitory concentration: 84 nM
Compound 4: the middle estimate sits 3.0-fold (0.47 log units) above what was measured; measured number inside the range.
By their numbers in this assay, from the lowest: compound 4; then compound 3; then compound 1; then compound 2.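

On this carbon, ortho to a methoxy group, the three measured groups now fall in a clear order in this assay, with amino ahead of both fluoro and methyl: a 5.0-fold lower number from compound 3 to compound 4 (0.69 log units; beyond the scatter) and a 76-fold lower number from compound 1 to compound 4 (1.88 log units; beyond the scatter) are both steps beyond the scatter. Fluoro therefore did not mark the limit at this position. Among these compounds, with the whole benzyl aryl group changed, 3-amino-4-methoxyphenyl in place of 4-methylphenyl gives a 650-fold lower number from compound 2 to compound 4 (2.81 log units; beyond the scatter) and spans the full range of the series so far. No measurement on hand accounts for the step from fluoro to amino.

On these data alone, whether the lower number is particular to amino stays open, and a hydroxyl, methylamino or acetamido group on this carbon would test that. Also open, as far as these compounds go, is whether amino keeps its effect without the neighbouring methoxy group, as in a 3-aminobenzyl analogue.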